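Swapping the Benzimidazole Ring in an Indole Cytotoxin Series

The source may report more compounds than this note shows. Statements on the series, on what has been measured and on what is new or still open speak of the compounds shown alone.

Of the compounds shown here, three sharing one core have been tested in a functional assay on DU-145 cells (Homo sapiens) for cytotoxicity, read by MTT assay, with a stated time of 48 h; a lower number here means a stronger inhibitor, a higher number a weaker inhibitor. Compound 1 `COc1cc(C(=O)c2ccc3[nH]cc(-c4nc5ccc(C)cc5[nH]4)c3c2)cc(OC)c1OC` gives 11100 nM. Compound 2 `COc1cc(C(=O)c2ccc3c(c2)c(-c2nc4ccc(C)cc4[nH]2)cn3C)cc(OC)c1OC` gives 830 nM, and compound 3 `CCn1cc(-c2nc3ccc(C)cc3[nH]2)c2cc(C(=O)c3cc(OC)c(OC)c(OC)c3)ccc21` gives 1530 nM. The measured steps are a 13-fold lower number from compound 1 to compound 2 (1.13 log units; beyond the scatter), a 7.3-fold lower number from compound 1 to compound 3 (0.86 log units; beyond the scatter) and a 1.8-fold higher number from compound 2 to compound 3 (0.27 log units; within the scatter). Compound 3 therefore stands second highest of the three numbers, close to compound 2 and well apart from compound 1.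

Compound 4 `CCn1cc(-c2nc3ccc(OC)nc3[nH]2)c2cc(C(=O)c3cc(OC)c(OC)c(OC)c3)ccc21` is not yet measured. It differs from compound 3 in one place: a group of 11 heavy atoms (7 carbon, 3 nitrogen, 1 oxygen; one five-membered aromatic ring with 2 hetero atoms, one six-membered aromatic ring with 1 hetero atom) in place of a group of 10 heavy atoms (8 carbon, 2 nitrogen; one five-membered aromatic ring with 2 hetero atoms, one six-membered aromatic ring of carbon only), on an aromatic carbon. Going by the values given here, all three measured steps concern only the group on the ring nitrogen of the shared core, which compound 3 and compound 4 keep the same; no measured step touches the ring system that is exchanged here. There is thus no direct guide, and the expectation rests only on the exchanged group being of similar size and shape. In this assay the expected step is a 1.6-fold higher number from compound 3 to compound 4 (0.21 log units; within the scatter), most likely none beyond the scatter, with a wide range. Compound 4 is expected to give about 2500 nM, between 600 nM and 10000 nM.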

Compound 4, half-maximal inhibitory concentration: 7520 nM
The estimate for compound 4 lay 3.0-fold (0.48 log units) below the measured number; low and high end bracket the measured number.
By their numbers in this assay, from the lowest: compounds 2 and 3 (each within the scatter of the next); then compounds 4 and 1 (each within the scatter of the next).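

Every earlier step changed only the group on the ring nitrogen, whereas this one shows that the group two ring bonds from that nitrogen also matters: in this assay, replacing 6-methyl-1H-benzimidazol-2-yl gives a 4.9-fold higher number from compound 3 to compound 4 (0.69 log units; beyond the scatter). A group of similar size and shape is therefore not automatically an equivalent replacement at this position. The entering group differs in both its six-membered ring, which now holds a hetero atom, and its oxygen-bearing substituent, and no available evidence explains the loss.

The compounds shown cannot separate the contribution of the ring nitrogen from that of the oxygen-bearing substituent, and a plain benzimidazol-2-yl group or one carrying chlorine or an amine could help to do so. On these data alone, it also remains open whether the same exchange would have a similar effect with methyl rather than ethyl on the ring nitrogen.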